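The compounds below may be only part of what the source reports. "The series", "measured", "known", "first", "only" and "open" are said of these compounds alone.

Working notes on the cinnamamide series. In a functional assay on HeLa cells (Homo sapiens) for cytotoxicity, read by MTT assay, with a stated time of 72 h (a lower number here means a stronger inhibitor, a higher number a weaker inhibitor), compound 1 `O=C(/C=C/c1ccc([N+](=O)[O-])cc1)Nc1cc2c(Nc3ccc(F)c(Cl)c3)ncnc2cc1O[C@H]1CCOC1` gives 27400 nM. Among the measured compounds shown here, compound 2 `O=C(/C=C/c1cccc(Cl)c1Cl)Nc1cc2c(Nc3ccc(F)c(Cl)c3)ncnc2cc1O[C@H]1CCOC1` gives 30500 nM in this assay; this is the highest of the two numbers so far, with compound 1 nearest, and the two lie within the scatter of each other. Compound 3 `COc1cc(/C=C/C(=O)Nc2cc3c(Nc4ccc(F)c(Cl)c4)ncnc3cc2OC)cc(OC)c1` has "not determined" (no result reported) in this assay, so it contributes no number. For the measured compounds named here, the only measured step is a 1.1-fold higher number from compound 1 to compound 2 (0.05 log units; within the scatter), a change of the aryl group on the double-bonded chain carbon bound to a double-bonded chain carbon.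

Compound 4 `O=C(/C=C/c1ccc(Br)cc1)Nc1cc2c(Nc3ccc(F)c(Cl)c3)ncnc2cc1O[C@H]1CCOC1` is not yet measured in this assay. It differs from compound 2 by 4-bromophenyl in place of 2,3-dichlorophenyl on a double-bonded chain carbon bound to a double-bonded chain carbon. Going by the values given here, the one step that bears on this, from compound 1 to compound 2, also exchanged the aryl group at this place and stayed within the scatter, so no step beyond the scatter is expected in this assay for compound 4 either. The step of a 1.1-fold lower number from compound 2 to compound 4 (0.04 log units; within the scatter) is what this estimate amounts to. Compound 4 is therefore expected to give about 28000 nM in this assay, with a range from 12000 nM to 70000 nM.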

Compound 4, half-maximal inhibitory concentration: 27500 nM
The estimate for compound 4 lay 1.0-fold (0.01 log units) above the measured number; the range from low to high includes it.
By their numbers in this assay, from the lowest: compounds 1, 4 and 2 (each within the scatter of the next).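

In this assay, 4-bromophenyl in place of 2,3-dichlorophenyl on a double-bonded chain carbon bound to a double-bonded chain carbon gives a 1.1-fold lower number from compound 2 to compound 4 (0.04 log units; within the scatter), so a third aryl group at this place falls within the scatter of the second. Bromo in place of nitro on an aromatic carbon gives a 1.0-fold higher number from compound 1 to compound 4 (0.00 log units; within the scatter), which adds a comparison where only one substituent on the aryl ring differs, and the 4-nitrophenyl, 2,3-dichlorophenyl and 4-bromophenyl compounds cannot be told apart by their numbers. Nothing available here bears on why these numbers lie so close.

Going by these compounds, whether an amine or a carboxylic acid on this aryl ring, or a longer chain in place of the ring, would stay within the same scatter remains open. On these data alone, all three measured compounds share one core, so whether this holds on another core also remains open.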